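This account rests on a few compounds, and the source may have more. Where it says the series, first, only, none or still open, it means among the compounds named here.

The series is measured in a functional assay on CHO-K1 cells for antagonist activity at C-X-C chemokine receptor type 3 (Homo sapiens), read by FLIPR and calcium flux; a higher number here means a weaker inhibitor, a lower number a stronger inhibitor. Compound 1 `CC1CN(S(=O)(=O)C[C@]23CC[C@H](CC2=O)C3(C)C)CCN1c1ccc(C(F)(F)F)cn1` gives 316 nM in this assay, the lowest of the two numbers reported; the nearest, compound 2 `CC1CN(c2ccc(C(F)(F)F)cn2)CCN1S(=O)(=O)C[C@]12CC[C@H](CC1=O)C2(C)C`, gives 631 nM, a gap that lies within the usual scatter, so the two are not ordered against each other. Compound 3 `CC1(C)[C@@H]2CC[C@@]1(CS(=O)(=O)N1C[C@@H]3C[C@H]1CN3c1ccc(C(F)(F)F)cn1)C(=O)C2` is reported only as a limit of this assay, > 31600 nM, and the limit of > 31600 nM in this assay, at which 1 of the 3 values shown sits, describes it. For the measured compounds named here, no pair among the measured compounds differs in a single place, so no measured step is available as a guide.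

Compound 4 `C[C@@H]1CN(S(=O)(=O)C[C@]23CC[C@H](CC2=O)C3(C)C)CCN1c1ccc(C(F)(F)F)cn1` is the compound still to be measured. It differs from compound 1 thus: the two compounds have the same atoms and bonds; at least one stereo element is drawn with a configuration in one of them and without one in the other: 1 of 3 stereo elements differ; a stereocentre at a saturated ring carbon is drawn without a configuration in compound 1 and R in compound 4. In words, the two compounds have the same atoms and bonds, and a stereocentre at a saturated ring carbon is drawn without a configuration in compound 1 and R in compound 4. With the configuration fixed, the expected step from compound 1 to compound 4 is a 1.3-fold lower number from compound 1 to compound 4 (0.10 log units; within the scatter), which is not clearly beyond the scatter in either direction. Compound 4 is accordingly estimated at 250 nM in this assay, with a range from 100 nM to 1000 nM.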

Compound 4, half-maximal inhibitory concentration: 501 nM
Estimate against measurement, compound 4: 2.0-fold (0.30 log units) below; the range from low to high includes it.
By their numbers in this assay, from the lowest: compounds 1, 4 and 2 (each within the scatter of the next). At a limit, above all of these: compound 3.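

This gives the series its first measured step in this assay: drawing the stereocentre at the saturated ring carbon as R gives a 1.6-fold higher number from compound 1 to compound 4 (0.20 log units; within the scatter). Compound 4 therefore cannot be told apart from compound 1, and the defined R form gives a number in the same range as the form drawn without a configuration. How much this says about the configuration itself is limited by one fact: the fact that one of compounds 1 and 4 is drawn with a defined configuration and the other without, at the place where they differ

From the compounds shown here alone, whether the S configuration at this stereocentre would give a different number stays open, as does the effect of an ethyl or a hydroxymethyl group in place of the methyl. Compound 3 is reported only as a limit of this assay, > 31600 nM, and it differs from compound 1 in more than one place, so it does not settle either question.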